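Amide aryl exchange on a bile acid receptor agonist core

A few compounds are considered here, and "the series" means these few. Any claim that something is new, unique, unknown or untested is made for them only; others in the source may bear on it.

Measured compounds:
compound 1 `CC(C)OC(=O)C1CN(C(=O)c2cccc(Cl)c2)CC(C)(C)c2cc(C#N)[nH]c21`: 103%
compound 2 `CC(C)OC(=O)C1=CN(C(=O)C2CCCCC2)CC(C)(C)c2cc(C#N)[nH]c21`: 124%
compound 3 `CC(C)OC(=O)C1=CN(C(=O)c2ccc(F)c(F)c2)CC(C)(C)c2cc(C#N)[nH]c21`: 121%

In an assay on HEK293 cells for agonist activity at Bile acid receptor (Homo sapiens), read by a luciferase reporter (on this read-out lower numbers stand for smaller maximal responses and higher numbers for larger maximal responses), compound 1 gives 103%, the lowest of the three values. Compound 3 gives 121% and compound 2 gives 124%; each of these stands beyond the scatter above compound 1, while the two of them lie within the scatter of each other.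

Compound 4 `CC(C)OC(=O)C1CN(C(=O)c2ccc(F)cc2)CC(C)(C)c2cc(C#N)[nH]c21` differs from compound 1 in one place: 4-fluorophenyl in place of 3-chlorophenyl on a carbonyl carbon. Among the measured compounds shown here, the only measured step that changes a single place is a number 3 percentage points lower from compound 2 to compound 3 (within the scatter), which exchanges cyclohexyl for 3,4-difluorophenyl and so is a larger change than the one from compound 1 to compound 4; it also sits on a different core. For the measured compounds named here, no measured step exchanges one halogenated phenyl for another, so the direction of the present change is not fixed by the data. Going by the values given here, since the one step available stayed within the scatter, no step beyond the scatter is expected here either, and the estimated change is a number 1 percentage points lower from compound 1 to compound 4 (within the scatter).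

Compound 4 is therefore expected to give 102% in this assay, with a range from 86% to 118%.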

Compound 4, largest response reached (reported as efficacy), in percent of the reference or control that the assay uses: 85%
For compound 4 the middle estimate is 17 percentage points above the measured one, and the stated range ends above it.
By their numbers in this assay, from the lowest: compound 4; then compound 1; then compounds 3 and 2 (each within the scatter of the next).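

In this assay, the exchange of 3-chlorophenyl for 4-fluorophenyl on a carbonyl carbon reads as a number 18 percentage points lower from compound 1 to compound 4 (beyond the scatter). The maximal response at this position therefore depends on which halogenated phenyl is present, even though the two groups match in count of heavy atoms and carry no hydrogen-bond donors, hydrogen-bond acceptors or net charge; the size of an exchange gives no guide here, since the step from cyclohexyl to 3,4-difluorophenyl on a different core, a number 3 percentage points lower from compound 2 to compound 3 (within the scatter), stayed within the scatter. Nothing available gives a reason for this step.

The compounds shown do not separate the identity of the halogen from its place on the ring, and 4-chlorophenyl or 3-fluorophenyl on the same carbonyl carbon of the core of compound 1 would divide these two factors. Also open, as far as these compounds go, is whether the same exchange has a similar effect on the core of compound 2, and whether a plain phenyl or 4-methoxyphenyl group would match compound 1 at 103%.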